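Replacing the nitrophenyl group with a hydroxynaphthyl group

The source may report more compounds than this note shows. Statements on the series, on what has been measured and on what is new or still open speak of the compounds shown alone.

Measured compounds:
- compound 1 `COc1cc(CC2C(C#N)=C(N)N(c3ccc(S(N)(=O)=O)cc3)C3=C2C(=O)CCC3)ccc1O`: 25 ug/mL
- compound 2 `N#CC1=C(N)N(c2ccc(S(N)(=O)=O)cc2)C2=C(C(=O)CCC2)C1c1ccc([N+](=O)[O-])cc1`: 2.5 ug/mL

In a functional assay on Ehrlich cells (Mus musculus) for antiproliferative activity, read by trypan blue exclusion, with a stated time of 2 h (a lower number here means a stronger inhibitor, a higher number a weaker inhibitor), compound 2 gives 2.5 ug/mL, the lowest of the two numbers, while compound 1 gives 25 ug/mL. For the measured compounds named here, the one step between them, a 10-fold lower number from compound 1 to compound 2 (1.00 log units; beyond the scatter), is the only measured comparison available, and it involves 2-hydroxynaphthalen-1-yl in place of 4-nitrophenyl on a saturated ring carbon only in part: it swaps one group on the same saturated ring carbon for another, but neither of those groups is the 2-hydroxynaphthalen-1-yl group. Compound 3 `N#CC1=C(N)N(c2ccc(S(N)(=O)=O)cc2)C2=C(C(=O)CCC2)C1c1c(O)ccc2ccccc12` differs from compound 2 by 2-hydroxynaphthalen-1-yl in place of 4-nitrophenyl on a saturated ring carbon. The new group, like the 4-nitrophenyl group of compound 2, attaches its aromatic ring directly to that carbon, but it also carries a hydroxyl group, as the group of compound 1 did. Going by the values given here, with only one related step to lean on, a modest move toward a higher number in this assay is expected, but with wide uncertainty. Compound 3 is therefore estimated at 6 ug/mL, between 2 ug/mL and 20 ug/mL, which corresponds to an expected step of a 2.4-fold higher number from compound 2 to compound 3 (0.38 log units; beyond the scatter).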

Compound 3, half-maximal inhibitory concentration: > 100 ug/mL
Compound 3 gave a limit, no number; the forecaster's own chance of this, stated with the estimate: 5%; middle value at least 16-fold (1.22 log units) from the limit.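

In this assay compound 3 gives > 100 ug/mL, which is a limit of the assay and not a number. Exchanging the group on the saturated ring carbon gives an at least 40-fold higher number from compound 2 to compound 3 (1.60 log units; beyond the scatter), and the comparison with the other earlier compound gives an at least 4.0-fold higher number from compound 1 to compound 3 (0.60 log units; beyond the scatter), so this position can separate compounds even more sharply than the first pair showed. Attaching an aromatic ring directly to that carbon, as in compound 2 and compound 3, therefore does not by itself keep the number low, and neither does a hydroxyl group on the entering group, which compound 1 and compound 3 both carry.

The true size of both steps stays unknown, as only one side of compound 3's value is fixed: the limit of > 100 ug/mL in this assay, at which 1 of the 3 values shown sits. The compounds shown also leave open whether the second aromatic ring or the hydroxyl group of 2-hydroxynaphthalen-1-yl goes with the change, a question that a 1-naphthyl or a 2-hydroxyphenyl group on the same carbon could help to separate.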